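Benzyl for isopropyl on the amide of compound 3

The compounds below may be only part of what the source reports. "The series", "measured", "known", "first", "only" and "open" are said of these compounds alone.

Measured so far:
- compound 1, `O=C(NCc1ccccc1)c1cc(Oc2cccc(NC(=S)Nc3cccc(C(F)(F)F)c3)c2)ccn1`: 7500 nM
- compound 2, `CNC(=O)c1cc(Oc2cccc(NC(=S)Nc3ccc(OC(F)(F)F)cc3)c2)ccn1`: 33800 nM
- compound 3, `CC(C)NC(=O)c1cc(Oc2cccc(NC(=S)Nc3ccc(OC(F)(F)F)cc3)c2)ccn1`: 18100 nM

In a functional assay on HCT-116 cells (Homo sapiens) for cytotoxicity, read by MTT assay, with a stated time of 48 h (a lower number here means a stronger inhibitor, a higher number a weaker inhibitor), compound 3 gives 18100 nM, the second highest of the three numbers. Its nearest neighbour is compound 2 with 33800 nM, a difference within the scatter. Compound 1 gives 7500 nM, and the gap from compound 3 to compound 1 is the only one of the three that lies outside the scatter. Compound 4, `O=C(NCc1ccccc1)c1cc(Oc2cccc(NC(=S)Nc3ccc(OC(F)(F)F)cc3)c2)ccn1`, is not yet measured. The change from compound 3 to compound 4 is benzyl in place of isopropyl on an amide-type nitrogen. Within the data shown here, one measured step bears on this: a 1.9-fold lower number from compound 2 to compound 3 (0.27 log units; within the scatter), where the larger group on the amide nitrogen went with a number within the scatter of the smaller one. Compound 1 also carries a benzyl on that nitrogen, though the rest of its structure differs, so its value cannot be tied to this change alone. The expected step from compound 3 to compound 4 is therefore a modest fall in the number, a 2.3-fold lower number from compound 3 to compound 4 (0.35 log units; beyond the scatter), of a size near what compound 1 shows against compound 3. Compound 4 is expected to give 8000 nM, with a range from 3000 nM to 25000 nM in this assay.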

Compound 4, half-maximal inhibitory concentration: 7400 nM
The estimate for compound 4 lay 1.1-fold (0.03 log units) above the measured number; the range from low to high includes it.
By their numbers in this assay, from the lowest: compounds 4 and 1 (each within the scatter of the next); then compounds 3 and 2 (each within the scatter of the next).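

In this assay, among these compounds, benzyl on the amide-type nitrogen gives the first step at this position that lies beyond the scatter, a 2.4-fold lower number from compound 3 to compound 4 (0.39 log units; beyond the scatter), and the same holds against the methyl amide, a 4.6-fold lower number from compound 2 to compound 4 (0.66 log units; beyond the scatter). With benzyl held in place, 4-(trifluoromethoxy)phenyl in place of 3-(trifluoromethyl)phenyl on the other amide-type nitrogen gives a 1.0-fold lower number from compound 1 to compound 4 (0.01 log units; within the scatter), so the two benzyl compounds cannot be told apart in this assay. Nothing available offers an explanation for these steps.

What a cyclohexylmethyl or 2-phenylethyl group on the amide nitrogen would give remains open, so the compounds shown do not separate the aromatic ring of benzyl from its carbon count. Also open, on these data alone, is the effect of an amine or a carboxylic acid on the benzyl ring.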